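This account rests on a few compounds, and the source may have more. Where it says the series, first, only, none or still open, it means among the compounds named here.

Working notes on the urea series.

Of the compounds shown here, two have numbers so far. Compound 1 `Cc1cc(NC(=O)Nc2ccccc2F)c2ccccc2n1` gives 3800 nM in a physicochemical assay for solubility, at pH 7.4 (on this read-out higher numbers stand for higher solubility and lower numbers for lower solubility), and compound 2 `Cc1cc(NC(=O)Nc2ccc(O)cc2)c2ccccc2n1` gives 100 nM. Among the compounds with values here, the one measured step, a 38-fold lower number from compound 1 to compound 2 (1.58 log units; beyond the scatter), pairs a 4-hydroxyphenyl in place of a 2-fluorophenyl on an amide-type nitrogen. On the numbers shown, compound 2 stands lowest of the two, with compound 1 beyond the scatter above it.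

Compound 3 `Cc1cc(NC(=O)Nc2ccc(SC(F)(F)F)cc2)c2ccccc2n1` is not yet measured. It differs from compound 2 by (trifluoromethyl)sulfanyl in place of hydroxy on an aromatic carbon, on an aromatic carbon of a six-membered aromatic ring of carbon only, para to a large group. Within the data shown here, no measured step bears directly on this exchange; the single step from compound 1 to compound 2 changes both the group and its place, so it gives only loose guidance. The expectation for compound 3 is therefore a modest step, a 1.7-fold lower number from compound 2 to compound 3 (0.22 log units; within the scatter), with no firm direction beyond the scatter. Compound 3 is estimated at 60 nM, within 12 nM to 300 nM.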

Compound 3, solubility: 200 nM
Beside the measured number, compound 3's estimate is 3.3-fold (0.52 log units) below it; the range from low to high includes it.
By their numbers in this assay, from the lowest: compounds 2 and 3 (each within the scatter of the next); then compound 1.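

In this assay, (trifluoromethyl)sulfanyl in place of hydroxy, on an aromatic carbon para to a large group, gives a 2.0-fold higher number from compound 2 to compound 3 (0.30 log units; within the scatter) and so does not separate the two compounds. Within the data shown here, this is the first measured exchange confined to this one place, and the swap of a hydroxy group for a larger group with no hydrogen-bond donor leaves the read-out within the scatter. No supporting measurement explains this result.

From the compounds shown here alone, it remains open whether a carboxylic acid or an amine at this same place would also stay within the scatter of compound 2, or would move the read-out beyond it. Also open, going by these compounds, is how much of the large step between compound 1 and compound 2 belongs to the place of the substituent and how much to the group itself.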